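This account rests on a few compounds, and the source may have more. Where it says the series, first, only, none or still open, it means among the compounds named here.

In a functional assay on HepG2 cells (Homo sapiens) for cytotoxicity, read by sulforhodamine B assay, with a stated time of 72 h (on this read-out higher numbers stand for weaker inhibition and lower numbers for stronger inhibition), compound 1 `Cc1c(-c2csc(/N=C3\S/C(=C\c4ccccc4)C(=O)N3c3ccccc3)n2)c(=O)n(-c2ccccc2)n1C` gives 63400 nM, while compound 2 `COc1ccc(/C=C2\S/C(=N\c3nc(-c4c(C)n(C)n(-c5ccccc5)c4=O)cs3)N(c3ccccc3)C2=O)cc1` gives 13200 nM. Going by the values given here, the only measured step, a 4.8-fold lower number from compound 1 to compound 2 (0.68 log units; beyond the scatter), came from a methoxy in place of hydrogen on an aromatic carbon, so compound 2 stands lowest of the two numbers. Compound 3 `Cc1ccc(/C=C2\S/C(=N\c3nc(-c4c(C)n(C)n(-c5ccccc5)c4=O)cs3)N(c3ccccc3)C2=O)cc1` differs from compound 2 by methyl in place of methoxy on an aromatic carbon. Among the compounds with values here, no measured step swaps methyl for methoxy; the one that bears on it, a 4.8-fold lower number from compound 1 to compound 2 (0.68 log units; beyond the scatter), only tells how much that spot can move the number. A modest rise in this assay is therefore expected, a 1.7-fold higher number from compound 2 to compound 3 (0.22 log units; within the scatter). For compound 3 the estimate is 22000 nM, between 8000 nM and 60000 nM.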

Compound 3, half-maximal inhibitory concentration: > 100000 nM
Compound 3 ended at the assay's limit (the forecaster's own chance of this, stated with the estimate: 5%); at least 4.5-fold (0.65 log units) between middle value and limit.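

Replacing 4-methoxyphenyl with 4-methylphenyl in this assay gives an at least 7.5-fold higher number from compound 2 to compound 3 (0.87 log units; beyond the scatter) and shows that the lower number at this spot, para to a large group, does not come with just any added group. For compound 3 the reading of > 100000 nM is a limit of the assay, not a number. Methyl in place of hydrogen gives an at least 1.5-fold higher number from compound 1 to compound 3 (0.19 log units; that floor lies within the scatter) and so, unlike methoxy, brings no lowering of the number here.

Still open, going by these compounds, is whether a hydroxyl or an amine on this carbon would lower the number further.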